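The source may report more compounds than this note shows. Statements on the series, on what has been measured and on what is new or still open speak of the compounds shown alone.

Measured in a functional assay on MCF7 cells (Homo sapiens) for antiproliferative activity, read by MTT assay, with a stated time of 48 h; on this read-out higher numbers stand for weaker inhibition and lower numbers for stronger inhibition:
- compound 1 `COc1ccc(C2=N/C(=C\c3cc(Br)cc(Br)c3OC(C)=O)C(=O)NN2C(N)=S)cc1OC`: 13400 nM
- compound 2 `CC(=O)Oc1c(Br)cc(Br)cc1/C=C1\N=C(c2ccccc2)N(c2ncc(-c3ccc(Br)cc3)s2)NC1=O`: 9490 nM
- compound 3 `COc1ccc(C2=N/C(=C\c3cc(Br)cc(Br)c3OC(C)=O)C(=O)NN2c2ncc(-c3ccccc3)s2)cc1OC`: 4330 nM

Compound 3 has the lowest number of the three, beyond the scatter from both others. The next compound is compound 4 `COc1ccc(C2=N/C(=C\c3cc(Br)cc(Br)c3OC(C)=O)C(=O)NN2c2ncc(-c3ccc(Br)cc3)s2)cc1OC`, with bromo in place of hydrogen on an aromatic carbon, phenyl to 4-bromophenyl. Among the compounds with values here, no measured step isolates this change. The closest is a 3.1-fold lower number from compound 1 to compound 3 (0.49 log units; beyond the scatter), a modest step from a far larger replacement. Compound 2 carries the 4-bromophenyl group and gives 9490 nM, but it also differs elsewhere from compound 4. In this assay, no step beyond the scatter is expected, and no firm direction. The expected result is a 1.1-fold lower number from compound 3 to compound 4 (0.03 log units; within the scatter). For compound 4 the estimate is 4000 nM, with an expected range of 1700 nM to 9500 nM.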

Compound 4, half-maximal inhibitory concentration: 3280 nM
The estimate for compound 4 lay 1.2-fold (0.09 log units) above the measured number, and the stated range covers the measured number.
By their numbers in this assay, from the lowest: compounds 4 and 3 (each within the scatter of the next); then compounds 2 and 1 (each within the scatter of the next).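

In this assay, phenyl to 4-bromophenyl gives a 1.3-fold lower number from compound 3 to compound 4 (0.12 log units; within the scatter), so bromo at this position, para to a large group, brings no step beyond the scatter. With that group held as 4-bromophenyl, 3,4-dimethoxyphenyl in place of phenyl gives a 2.9-fold lower number from compound 2 to compound 4 (0.46 log units; beyond the scatter), and the larger group on the ring amine nitrogen gives a 4.1-fold lower number from compound 1 to compound 4 (0.61 log units; beyond the scatter) in a modest step. No measurement here bears on the reason for these steps. Still open, on these data alone, is whether another group at this position, such as an amine or a carboxylic acid, would move the number beyond the scatter.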